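The compounds below may be only part of what the source reports. "The series", "measured", "known", "first", "only" and "open" are said of these compounds alone.

Compound 1 `O=C1N=C(N2N=C(c3ccccc3)CC2c2ccccc2O)S/C1=C1/C(=O)Nc2ccc(Br)cc21` in a functional assay on cells (Cancer cell lines, Homo sapiens) for cytotoxicity, read by sulforhodamine B assay, with a stated time of 48 h (a lower number here means a stronger inhibitor of growth, a higher number a weaker inhibitor of growth), gives 290 nM. Compound 2 `CN(C)c1ccc(C2CC(c3ccccc3)=NN2C2=NC(=O)/C(=C3\C(=O)Nc4ccccc43)S2)cc1` in this assay gives 270 nM. Compound 3 `CN(C)c1ccc(C2CC(c3ccccc3)=NN2C2=NC(=O)/C(=C3\C(=O)Nc4ccc(Br)cc43)S2)cc1` in this assay gives 270 nM.

Compound 3 sits level with compound 2 in this assay; together they hold the lowest numbers of the three, with compound 1 close by and not separated from them beyond the scatter. Both measured steps into compound 3 are small: a 1.1-fold lower number from compound 1 to compound 3 (0.03 log units; within the scatter) swapped 4-(dimethylamino)phenyl for 2-hydroxyphenyl on a saturated ring carbon, and no change at the digits printed from compound 2 to compound 3 (within the scatter) placed bromo where hydrogen had been on an aromatic carbon, without moving the number.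

Compound 4 `CN(C)c1ccc(C2CC(c3ccccc3)=NN2C2=NC(=O)/C(=C3\C(=O)Nc4ccc(Cl)cc43)S2)cc1` differs from compound 3 in one place: chloro in place of bromo on an aromatic carbon. The step that bears directly on this change is no change at the digits printed from compound 2 to compound 3 (within the scatter). It concerns the same aromatic carbon and shows that hydrogen and bromo there give the same number. A chloro at that carbon is therefore expected to leave the number essentially where it is, an expected step of no change at the digits printed from compound 3 to compound 4 (within the scatter). The estimate for compound 4 in this assay is 270 nM, expected to fall between 150 nM and 500 nM.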

Compound 4, concentration for 50% growth inhibition: 250 nM
Compound 4: middle estimate off by 1.1-fold (0.03 log units), on the high side; the range from low to high includes it.
By their numbers in this assay, from the lowest: compounds 4, 2, 3 and 1 (each within the scatter of the next).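

In this assay chloro in place of bromo gives a 1.1-fold lower number from compound 3 to compound 4 (0.03 log units; within the scatter) and chloro in place of hydrogen gives a 1.1-fold lower number from compound 2 to compound 4 (0.03 log units; within the scatter). Hydrogen, chloro and bromo can now all be compared at this aromatic carbon on otherwise the same structure, and none stands apart from the others, so the lack of separation seen earlier between hydrogen and bromo extends to a second halogen. Nothing available explains why these replacements leave the number in place.

Going by these compounds, whether a different kind of group at this carbon, such as an amine or a carboxylic acid, would also leave the number in place remains open. So does whether chloro would match bromo with 2-hydroxyphenyl on the saturated ring carbon, as in compound 1 , instead of 4-(dimethylamino)phenyl.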